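Swapping fluoro for methylamino on a weak cytotoxic compound

The source may report more compounds than this note shows. Statements on the series, on what has been measured and on what is new or still open speak of the compounds shown alone.

The measured compounds and their values:
compound 1 `CC(C)(C)c1ccc(NC(=S)N/N=C2\C(=O)Nc3ccccc32)cc1`: 6800 nM
compound 2 `COc1cc(OC)cc(-c2ccc3c(c2)C(CC(=O)OCC2CC2)C(C(=O)OCC2CC2)=C(N)O3)c1`: 6700 nM
compound 3 `CCOC(=O)CC1C(C(=O)OCC)=C(N)Oc2ccc(-c3cccc(F)c3)cc21`: 76400 nM

In a functional assay on HL-60 cells (Homo sapiens) for cytotoxicity, read by CellTiter-Blue, with a stated time of 48 h (on this read-out lower numbers stand for stronger inhibition and higher numbers for weaker inhibition), compound 3 stands highest of the three numbers, far beyond the scatter from both compound 1 and compound 2, so it is the weakest inhibitor among them. Compound 4 `CCOC(=O)CC1C(C(=O)OCC)=C(N)Oc2ccc(-c3cccc(NC)c3)cc21` shares the core of compound 3 and differs only by methylamino in place of fluoro on an aromatic carbon. For the measured compounds named here, no measured pair shows this same change, so no direct guide exists. The step of a 1.9-fold lower number from compound 3 to compound 4 (0.28 log units; within the scatter) is expected to be small, toward a lower number, and may well fall within the scatter. Compound 4 is therefore estimated at 40000 nM, with a range from 8000 nM to 200000 nM.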

Compound 4, half-maximal inhibitory concentration: 7450 nM
Compound 4: the middle estimate sits 5.4-fold (0.73 log units) above what was measured; measured number below the stated range.
By their numbers in this assay, from the lowest: compounds 2, 1 and 4 (each within the scatter of the next); then compound 3.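

In this assay, this aromatic carbon, meta to a large group, proves sensitive to what it carries: replacing fluoro with methylamino gives a 10-fold lower number from compound 3 to compound 4 (1.01 log units; beyond the scatter). For the compounds shown here, a single change of 3-fluorophenyl to 3-(methylamino)phenyl is therefore enough to shift the number well past the scatter, which the earlier compounds could not show. Nothing available here explains why the number moves. Going by these compounds, it remains open whether a plain amine or a dimethylamino group at this place would give a similar number, and so whether the hydrogen on the nitrogen or the methyl matters.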